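A few compounds are considered here, and "the series" means these few. Any claim that something is new, unique, unknown or untested is made for them only; others in the source may bear on it.

Compound 1 `COc1ccc(/C=C/C(=O)OC[C@@H](OCc2ccccc2)[C@H]2OC(=O)C=C[C@H]2OCc2ccccc2)cc1`: > 100000 nM
Compound 2 `O=C1C=C[C@@H](OCc2ccccc2)[C@@H]([C@@H](COC(=O)/C=C/c2ccc([N+](=O)[O-])cc2)OCc2ccccc2)O1`: > 100000 nM

In an ADME assay on MRC5 cells (Homo sapiens) for cytotoxicity, read by MTT assay, with a stated time of 6 days (on this read-out lower numbers stand for stronger inhibition and higher numbers for weaker inhibition), compound 1 reaches only a limit of the assay, > 100000 nM. Compound 2 likewise reaches only a limit in this assay, > 100000 nM. The step from compound 1 to compound 2 in this assay, a step that the two limits leave unreadable from compound 1 to compound 2, cannot be read from two limits. Compound 3 `CC(=O)OC[C@@H](OCc1ccccc1)[C@H]1OC(=O)C=C[C@H]1OCc1ccccc1` is not yet measured. It differs from compound 2 in one place: methyl in place of 2-(4-nitrophenyl)ethenyl on a carbonyl carbon. Going by the values given here, no measured step covers this change; the single measured step bears on it only in that both values sit at the limit (the limit of > 100000 nM in this assay, at which 2 of the 2 values shown sit). The step from compound 2 to compound 3 in this assay, a number no higher from compound 2 to compound 3 (the limit leaves the size open), is therefore expected to be none beyond the scatter, with compound 3 most likely again at the limit. The expected value for compound 3 in this assay is 100000 nM, with a range from 40000 nM to 300000 nM.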

Compound 3, half-maximal inhibitory concentration: > 100000 nM
Compound 3: no number, only a limit; the forecaster's own chance of this, stated with the estimate: 80%; the middle value lies on the limit itself.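

In this assay, no step to compound 3 from compound 1 or compound 2 can be read, as all three values are limits: the limit of > 100000 nM in this assay, at which 3 of the 3 values shown sit.

The compounds shown leave open whether any of these changes shifts this read-out at all: none of the three gives a number.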